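This account rests on a few compounds, and the source may have more. Where it says the series, first, only, none or still open, it means among the compounds named here.

Measured compounds in an ADME assay on J774.1 cells (Mus musculus) for cytotoxicity, read by MTT assay, with a stated time of 48 h; on this read-out lower numbers stand for stronger inhibition and higher numbers for weaker inhibition:
compound 1 `Cc1c(C(=O)N/N=C/c2ccc([N+](=O)[O-])cc2)no[n+]1[O-]`: > 300000 nM
compound 2 `Cc1[nH]cnc1C(=O)N/N=C/c1ccc2no[n+]([O-])c2c1`: 33900 nM

The value for compound 1 is a limit of this assay and not a number, so only the limit of > 300000 nM in this assay, at which 1 of the 2 values shown sits, marks where it stands. Compound 2 gives a number, 33900 nM. The unmeasured compound 3 `CC(=O)Nc1ccc(/C=N/NC(=O)c2no[n+]([O-])c2C)cc1` differs from compound 1 by acetamido in place of nitro on an aromatic carbon. Going by the values given here, no measured step resembles this change, so the step from compound 1 to compound 3 is expected to be an at least 1.2-fold lower number from compound 1 to compound 3 (0.07 log units; that floor lies within the scatter) in this assay, nothing beyond the scatter. Compound 3 is therefore estimated at 250000 nM, between 80000 nM and 600000 nM, and may again come back only as a limit.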

Compound 3, half-maximal inhibitory concentration: 235000 nM
Compound 3: middle estimate off by 1.1-fold (0.03 log units), on the high side, and the stated range covers the measured number.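

Putting acetamido in place of nitro on the aromatic carbon para to a large group gives, in this assay, an at least 1.2-fold lower number from compound 1 to compound 3 (0.10 log units; that floor lies within the scatter). Going by these compounds, the true size of this step stays unknown because compound 1 gives only a limit of the assay: the limit of > 300000 nM in this assay, at which 1 of the 3 values shown sits. Compound 3, with acetamido at this place, gives a measured number in this assay, so the series now has a firm value at this position.

The compounds shown leave open what an amine or a carboxylic acid at this place would give, and whether a longer chain would move the number beyond the scatter.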